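The source may hold more compounds than are shown below. What is called first, only, known or untested is meant among the compounds shown, and "the series" means these compounds.

Measured in a functional assay (aorta) with Oryctolagus cuniculus as the target; on this read-out higher numbers stand for weaker inhibition and lower numbers for stronger inhibition:
- compound 1 `CC1=C(C)C(=O)C(C(CCCCCC(=O)O)c2ccc(F)cc2)=C(C)C1=O`: 48 nM
- compound 2 `CC1=C(C)C(=O)C(C(CCCCCC(=O)O)c2cccc(F)c2)=C(C)C1=O`: 1900 nM

Compound 2 has the higher of the two numbers. Compound 3 `CC1=C(C)C(=O)C(C(CCCCCC(=O)O)c2ccc(Br)cc2)=C(C)C1=O` differs from it by 4-bromophenyl in place of 3-fluorophenyl on a saturated chain carbon bound to a double-bonded ring carbon and a saturated chain carbon. Going by the values given here, one measured step bears on this change: a 40-fold higher number from compound 1 to compound 2 (1.60 log units; beyond the scatter), which is large and beyond the scatter. Among the compounds with values here, compound 3 carries 4-bromophenyl where compound 1 carries 4-fluorophenyl, but no bromine-bearing compound has yet been measured. A large drop, toward the value of compound 1 at 48 nM, is therefore expected, with some uncertainty. The expected step is a 32-fold lower number from compound 2 to compound 3 (1.50 log units; beyond the scatter). For compound 3 the estimated value is 60 nM, with an expected range of 15 nM to 250 nM.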

Compound 3, half-maximal inhibitory concentration: 1700 nM
Compound 3: the middle estimate sits 28-fold (1.45 log units) below what was measured; the whole stated range lies below it.
By their numbers in this assay, from the lowest: compound 1; then compounds 3 and 2 (each within the scatter of the next).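

In this assay, the 4-position of the phenyl ring is not enough on its own to give a low number: with bromo in place of fluoro on that aromatic carbon, the series shows a 35-fold higher number from compound 1 to compound 3 (1.55 log units; beyond the scatter), so the identity of the halogen matters here. 4-Bromophenyl and 3-fluorophenyl at this place are not told apart, with a 1.1-fold lower number from compound 2 to compound 3 (0.05 log units; within the scatter), leaving 4-fluorophenyl alone among the three with the low number. No evidence is at hand to account for this.

Open, on these data alone, is whether a plain phenyl or 4-chlorophenyl would stand with compound 1 or with compound 3. Also open, as far as these compounds go, is how 3-bromophenyl would compare with compound 2.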